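The compounds below may be only part of what the source reports. "The series", "measured", "known", "first", "only" and "open" are said of these compounds alone.

Measured so far:
compound 1, `CO/C(O)=C(/C=N/c1ccc(Oc2ccccc2OC(C)C)nc1)NC(=O)c1ccccc1` — 82%
compound 2, `Cc1c(Cc2c(Cl)cccc2Cl)c(=O)oc2cc(OCC(=O)OCC(=O)c3ccc(Cl)cc3)ccc12` — 80%

In a functional assay (Homo sapiens) for inhibition, tested at 10 uM (a lower number here means a weaker effect, a higher number a stronger effect of the compound at the concentration tested), compound 1 gives 82% and compound 2 gives 80%; the two numbers lie within the scatter of each other, so neither is set apart from the other. Compound 3, `Cc1c(Cc2c(Cl)cccc2Cl)c(=O)oc2cc(OCC(=O)OCC(=O)c3ccccc3)ccc12`, is not yet measured. It differs from compound 2 by hydrogen in place of chloro on an aromatic carbon. Among the measured compounds shown here, no measured pair shows a step of this kind, so the size of the step in this assay is expected to be small, most likely a modest drop that does not clearly exceed the scatter. Compound 3 is estimated at 70%, in the range 45% to 90%. The expected step is a number 10 percentage points lower from compound 2 to compound 3 (within the scatter).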

Compound 3, a percentage reported as inhibition, at one concentration (the size of the read-out at that concentration, not a potency): 66%
Compound 3: middle estimate off by 4 percentage points, on the high side; measured number inside the range.
By their numbers in this assay, from the lowest: compound 3; then compounds 2 and 1 (each within the scatter of the next).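

In this assay, the change from 4-chlorophenyl to phenyl gives a number 14 percentage points lower from compound 2 to compound 3 (beyond the scatter), the first step readable in this series. The chloro on this aromatic carbon, para to a large group, therefore contributes to the read-out at the concentration tested, although compound 3 still gives 66% without it. No measurement shown explains the size of this step.

From the compounds shown here alone, whether fluoro, methoxy or an amine at the same place would match chloro remains open. Also open, going by these compounds, is whether hydrogen in place of chloro elsewhere on the molecule gives a similar step.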